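The compounds below may be only part of what the source reports. "The series", "measured", "known", "first", "only" and "open" are said of these compounds alone.

Compound 1, `CC1(C)C=C(n2ccccc2=O)c2cc(C(=O)c3cccs3)ccc2O1`, gives 5.84 in a functional assay (trachea) with Rattus norvegicus as the target (a higher number here means a more potent compound, by a factor of ten per unit of this negative logarithm, a lower number a less potent compound), the second highest of three numbers. Compound 2, `CC1(C)C=C(n2ccccc2=O)c2cc(C(=O)c3ccc([N+](=O)[O-])cc3)ccc2O1`, gives 6.09, and compound 3, `CC1(C)C=C(n2ccccc2=O)c2cc(C(=O)c3ccccc3[N+](=O)[O-])ccc2O1`, gives 5.64. The step of a number 0.25 log units higher from compound 1 to compound 2 (within the scatter) and the step of a number 0.20 log units lower from compound 1 to compound 3 (within the scatter) both stay within the scatter, while a number 0.45 log units lower from compound 2 to compound 3 (beyond the scatter) is modest but real. Compound 4, `CC(=O)Oc1ccc2c(c1)C(n1ccccc1=O)=CC(C)(C)O2`, differs from compound 1 as follows: acetoxy in place of (thiophen-2-yl)carbonyl on an aromatic carbon. All three measured steps only exchange one aromatic ring for another on the carbonyl carbon, so none of them bears directly on removing the whole carbonyl-bearing group. Compound 4 is therefore expected with wide uncertainty to give 5.5 (range 4.7 to 6.3), which would mean an expected step of a number 0.34 log units lower from compound 1 to compound 4 (beyond the scatter).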

Compound 4, logarithm of the reciprocal of the active concentration, log(1/C): 4.97
Compound 4: middle estimate off by 0.53 log units, on the high side; measured number inside the range.
By their numbers in this assay, from the lowest: compound 4; then compounds 3, 1 and 2 (each within the scatter of the next, the first and the last beyond it).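

Replacing the whole (thiophen-2-yl)carbonyl with acetoxy gives a number 0.87 log units lower from compound 1 to compound 4 (beyond the scatter), a larger step than any exchange of one aromatic ring for another on the carbonyl carbon. The donor and acceptor counts of the two groups match, but acetoxy has fewer heavy atoms and no ring. No measurement available here shows which of these differences accounts for the step. Also open, as far as these compounds go, is whether the ring or the direct carbonyl attachment counts more: acetyl would keep the attachment without a ring, while benzoyloxy would keep a ring with the acetoxy-type oxygen link.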